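From propylamino to anilino on a shared core

The source may hold more compounds than are shown below. What is called first, only, known or untested is meant among the compounds shown, and "the series" means these compounds.

Compound 1 `O=C(Nc1ccc(Nc2nccc(NC3CC3)n2)cc1)Nc1ccc(Cl)c(C(F)(F)F)c1`: 16400 nM
Compound 2 `CCCNc1ccnc(Nc2ccc(NC(=O)Nc3ccc(Cl)c(C(F)(F)F)c3)cc2)n1`: 4240 nM

In a functional assay on HCT-116 cells (Homo sapiens) for antiproliferative activity, read by MTT assay, with a stated time of 72 h (a lower number here means a stronger inhibitor, a higher number a weaker inhibitor), compound 2 has the lower of the two numbers, at 4240 nM. Compound 3 `O=C(Nc1ccc(Nc2nccc(Nc3ccccc3)n2)cc1)Nc1ccc(Cl)c(C(F)(F)F)c1` alters one group of compound 2: phenyl in place of propyl on a nitrogen on an aromatic ring. Among the compounds with values here, only one measured step touches this place, a 3.9-fold lower number from compound 1 to compound 2 (0.59 log units; beyond the scatter), which is modest but beyond the scatter. Within the data shown here, no measured compound carries phenyl there, so the direction stays open and only a small change is expected. The estimated step is a 1.2-fold higher number from compound 2 to compound 3 (0.07 log units; within the scatter). The value expected for compound 3 is 5000 nM, with an estimated range of 1500 nM to 17000 nM.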

Compound 3, half-maximal inhibitory concentration: > 50000 nM
Compound 3: only a limit was reported; the forecaster's own chance of this, stated with the estimate: 5%; middle value at least 10-fold (1.00 log units) away from the limit.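

In this assay, the result for compound 3 is a limit, not an exact number: the limit of > 50000 nM in this assay, at which 1 of the 3 values shown sits. Phenyl in place of propyl gives an at least 11-fold higher number from compound 2 to compound 3 (1.07 log units; beyond the scatter), and phenyl in place of cyclopropyl gives an at least 3.0-fold higher number from compound 1 to compound 3 (0.48 log units; beyond the scatter). Compound 3 is therefore the weakest of the three, and the group on this nitrogen can matter much more than the earlier step between the two smaller groups showed.

The compounds shown do not explain this loss. They also leave open whether a butyl chain or a benzyl group here would behave like propyl or like phenyl.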